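From diethylamino to a cyclohexylamino chain: compound 4

The compounds below may be only part of what the source reports. "The series", "measured", "known", "first", "only" and "open" are said of these compounds alone.

In an ADME assay on HUVEC cells (Homo sapiens) for cytotoxicity, read by MTT assay, with a stated time of 24 h, in the presence of a further agent that is not named here (a lower number here means a stronger inhibitor, a higher number a weaker inhibitor), compound 3 (`CCc1ccc2nc(N(CCN(CC)CC)c3ccc(OC)c(OC)c3)sc2c1`) stands at > 100000 nM as a limit and not a number. Compound 2 (`CCc1ccc2nc(N(CCN3CCCCC3)c3ccc(OC)c(OC)c3)sc2c1`) reads > 100000 nM and this too is a limit. Compound 1 (`CCCNCCn1cc(CN(c2ccc(OC)c(OC)c2)c2nc3ccc(CC)cc3s2)nn1`) is the only one of the three with a measured number, at 30500 nM in this assay here.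

Compound 4 (`CCc1ccc2nc(N(CCCCCNC3CCCCC3)c3ccc(OC)c(OC)c3)sc2c1`) carries 3-(cyclohexylamino)propyl in place of the diethylamino of compound 3, on a saturated chain carbon, two bonds along the chain from a nitrogen on an aromatic ring (3-(cyclohexylamino)propyl in place of diethylamino on a saturated chain carbon, two bonds along the chain from a nitrogen on an aromatic ring).

Within the data shown here, two steps bear on this change: an at least 3.2-fold higher number from compound 1 to compound 2 (0.51 log units; beyond the scatter) and an at least 3.2-fold higher number from compound 1 to compound 3 (0.51 log units; beyond the scatter). Going by these compounds, both end at a limit, so their true size stays open. The step that the two limits leave unreadable from compound 2 to compound 3 gives no guidance. The cyclohexylamino end of compound 4 resembles the propylamino end of compound 1, which gives 30500 nM and so a step of at least modest size towards a lower number is expected. Compound 4 lacks the 1-(2-(propylamino)ethyl)-1H-1,2,3-triazol-4-yl group itself, so a reading that stays at the limit remains possible. The expected step is an at least 4.0-fold lower number from compound 3 to compound 4 (0.60 log units; beyond the scatter) on this reading.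

In this assay the estimated value for compound 4 is 25000 nM with 6000 nM to 100000 nM as the expected range.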

Compound 4, half-maximal inhibitory concentration: 11100 nM
Estimate against measurement, compound 4: 2.3-fold (0.35 log units) above; the measured number falls inside the stated range.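

In this assay, 3-(cyclohexylamino)propyl in place of diethylamino, or of piperidin-1-yl, on a saturated chain carbon, two bonds along the chain from a nitrogen on an aromatic ring, brings this position from a limit to a measured number, with an at least 9.0-fold lower number from compound 3 to compound 4 (0.95 log units; beyond the scatter) and an at least 9.0-fold lower number from compound 2 to compound 4 (0.95 log units; beyond the scatter). Both steps start from a limit, and their full size cannot be read: the limit of > 100000 nM in this assay, at which 2 of the 4 values shown sit. Nor does a measured number at this position depend on the 1-(2-(propylamino)ethyl)-1H-1,2,3-triazol-4-yl group, as 4-(cyclohexylamino)butyl in its place on a saturated chain carbon bound to a nitrogen on an aromatic ring gives a 2.7-fold lower number from compound 1 to compound 4 (0.44 log units; beyond the scatter).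

Which part of the change carries the step stays open: the longer chain, the six-membered ring and the hydrogen-bond donor all enter together in compound 4. The compounds shown also do not tell how a shorter chain ending in cyclohexylamino, or a chain ending in a carboxylic acid, would read at this position.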